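Side chain on the carbonyl: compound 2 to compound 3

A few compounds are considered here, and "the series" means these few. Any claim that something is new, unique, unknown or untested is made for them only; others in the source may bear on it.

Going by the values given here, in an ADME assay on HepG2 2.2.15 cells (Homo sapiens) for cytotoxicity (a higher number here means that more compound is tolerated, a lower number that less compound is tolerated), compound 2 `CC(=O)N1CCC(C(=O)OCCc2c(-c3ccccc3Cl)c3cc(Cl)ccc3[nH]c2=O)CC1` gives 82000 nM and compound 1 `N#CCC(=O)OCCc1c(-c2ccccc2Cl)c2cc(Cl)ccc2[nH]c1=O` gives 100000 nM on the only other number available, so the two sit within the scatter of each other and neither ranks.

Compound 3 `O=C(CCOc1ccccc1)OCCc1c(-c2ccccc2Cl)c2cc(Cl)ccc2[nH]c1=O` changes the side chain of compound 2 (2-phenoxyethyl in place of 1-acetylpiperidin-4-yl on a carbonyl carbon), with 2-phenoxyethyl in place of 1-acetylpiperidin-4-yl on a carbonyl carbon.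

Among the compounds with values here, only one measured step bears on this place: a 1.2-fold lower number from compound 1 to compound 2 (0.09 log units; within the scatter) with 1-acetylpiperidin-4-yl in place of cyanomethyl on a carbonyl carbon. That exchange of two unlike groups stayed within the scatter. Within the data shown here, no measured compound carries 2-phenoxyethyl, and a single step is thin evidence, so the range has to stay wide. The step expected in this assay is a 1.1-fold lower number from compound 2 to compound 3 (0.04 log units; within the scatter) as an estimate, which means none beyond the scatter. For compound 3 the estimated value is 75000 nM with an expected range from 30000 nM to 120000 nM as a working figure.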

Compound 3, half-maximal cytotoxic concentration: 46000 nM
Estimate against measurement, compound 3: 1.6-fold (0.21 log units) above, and the stated range covers the measured number.
By their numbers in this assay, from the lowest: compounds 3, 2 and 1 (each within the scatter of the next, the first and the last beyond it).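

In this assay, going by these compounds alone, the group on this carbonyl carbon now gives a first step beyond the scatter: the series shows a 2.2-fold lower number from compound 1 to compound 3 (0.34 log units; beyond the scatter) with phenoxymethyl in place of cyano on a saturated chain carbon bound to a carbonyl carbon. The other new step, a 1.8-fold lower number from compound 2 to compound 3 (0.25 log units; within the scatter) with 2-phenoxyethyl in place of 1-acetylpiperidin-4-yl, stays within the scatter, even though a non-aromatic ring with one hetero atom gives way to a chain ending in an aromatic ring of carbon only, so compound 2 cannot be separated from either of the other two compounds and only the two ends of the set differ. Nothing measured here accounts for either step.

From the compounds shown here alone, it remains open whether a carboxylic acid or a free amine on this side chain, or a longer chain ending in the same phenoxy group, would give a number beyond the scatter from compound 3. Going by these compounds, all three compounds also keep the same ester and the same core, so the effect of an amide in place of the ester is unknown in this assay.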